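A Larger Charged Head Group on Compound 2

The source may report more compounds than this note shows. Statements on the series, on what has been measured and on what is new or still open speak of the compounds shown alone.

Three compounds share one core and differ at the aromatic ring that carries the long chain or at the ring's substituent. Compound 1 `Cc1cc(-n2cc(C(=O)Nc3cc(F)cc(F)c3)c(=O)c3ccc(N(C)C)nc32)ccc1OCCCCCCC[N+]1(C)CCCC1`, compound 2 `Cc1ccc(-n2cc(C(=O)Nc3cc(F)cc(F)c3)c(=O)c3ccc(N(C)C)nc32)cc1OCCCCCCC[N+]1(C)CCCC1` and compound 3 `CN(C)c1ccc2c(=O)c(C(=O)Nc3cc(F)cc(F)c3)cn(-c3ccc(Cl)c(OCCCCCCC[N+]4(C)CCCC4)c3)c2n1` were all measured in an assay on LX2 cells for inhibition of COL1A1 promoter (Homo sapiens), read by a luciferase reporter, with a stated time of 24 h, tested at 20 uM; on this read-out higher numbers stand for a stronger effect at the one concentration tested and lower numbers for a weaker effect. Compound 2 gives 12.7%, the lowest of the three numbers, with compound 1 nearest at 26.1% and compound 3 furthest at 51%. Going by the values given here, the only one-place step in this set is a number 38.3 percentage points higher from compound 2 to compound 3 (beyond the scatter), and that step concerns a substituent on the aromatic ring, not the charged end of the chain.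

Compound 4 `Cc1ccc(-n2cc(C(=O)Nc3cc(F)cc(F)c3)c(=O)c3ccc(N(C)C)nc32)cc1OCCCCCCC[N+](C)(C)C1CCCCC1` differs from compound 2 at that end: a group of 9 heavy atoms (8 carbon, 1 nitrogen; one six-membered non-aromatic ring of carbon only) in place of a group of 6 heavy atoms (5 carbon, 1 nitrogen; one five-membered non-aromatic ring with 1 hetero atom), on a saturated chain carbon, seven bonds along the chain from an oxygen on an aromatic ring. Among the compounds with values here, no measured pair in this set varies the charged group at the end of the chain, so no step bears on this change, and the large step from compound 2 to compound 3 tells nothing about it. With nothing to point in either direction, the expectation for compound 4 in this assay is a number close to that of compound 2, with no step beyond the scatter. Compound 4 is therefore estimated at 15%, within a range from 0% to 35%. This estimate amounts to an expected a number 2.3 percentage points higher from compound 2 to compound 4 (within the scatter).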

Compound 4, a percentage reported as inhibition, at one concentration (the size of the read-out at that concentration, not a potency): 32.3%
Beside the measured number, compound 4's estimate is 17.3 percentage points below it; the range from low to high includes it.
By their numbers in this assay, from the lowest: compound 2; then compounds 1 and 4 (each within the scatter of the next); then compound 3.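

Going by these compounds alone, the charged end of the chain proves to be a position that responds to what it carries: in this assay, the new group gives a number 19.6 percentage points higher from compound 2 to compound 4 (beyond the scatter), which no earlier pair could show, since the only step before it concerned a substituent on the aromatic ring. Both groups carry a net charge of +1 and have 0 hydrogen-bond donors and 0 hydrogen-bond acceptors, so the step appears with these counted features unchanged, while the heavy-atom count and the ring differ. Nothing available here accounts for the size or direction of this step.

Within the data shown here, the one step changes several things together, the five-membered ring with its nitrogen giving way to a six-membered ring of carbon only and the heavy-atom count rising, so it cannot say which of these matters. The compounds shown leave open how a piperidine ring or a simple trimethylammonium group would read at the same place on the chain, and whether the step would hold with chloro in place of methyl on the aromatic ring.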